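This account rests on a few compounds, and the source may have more. Where it says the series, first, only, none or still open, it means among the compounds named here.

Compound 1 `Cc1ccc(/C=C/C(=O)Nc2ccc3c(c2)OCCO3)cc1` and compound 2 `CC(C)c1ccc(/C=C/C(=O)Nc2ccc3c(c2)OCCO3)cc1` share their core with compound 3 `O=C(/C=C/c1ccc(-c2ccccc2)cc1)Nc1ccc2c(c1)OCCO2` and differ from it only in one group on an aromatic carbon. In a functional assay on CHO cells for inhibition of transient receptor potential cation channel subfamily V member 1 (Homo sapiens) (on this read-out lower numbers stand for stronger inhibition and higher numbers for weaker inhibition), compound 1 gives 210 nM, and compound 2 gives 55 nM, so there is a 3.8-fold lower number from compound 1 to compound 2 (0.58 log units; beyond the scatter). Compound 3 reaches only the limit of this assay, > 4000 nM, which places it at the limit of > 4000 nM in this assay, at which 1 of the 3 values shown sits. The steps toward it were both large: an at least 19-fold higher number from compound 1 to compound 3 (1.27 log units; beyond the scatter) and an at least 72-fold higher number from compound 2 to compound 3 (1.86 log units; beyond the scatter). Compound 4 `O=C(/C=C/c1ccc(C(F)(F)F)cc1)Nc1ccc2c(c1)OCCO2` carries a (trifluoromethyl in place of phenyl on an aromatic carbon). Since the phenyl went with both large losses, its removal is expected to bring a large gain, an at least 33-fold lower number from compound 3 to compound 4 (1.52 log units; beyond the scatter). Compound 4 is therefore estimated at about 120 nM, with a range from 30 nM to 600 nM.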

Compound 4, half-maximal inhibitory concentration: 46 nM
For compound 4 the middle estimate is 2.6-fold (0.42 log units) above the measured one; the range from low to high includes it.
By their numbers in this assay, from the lowest: compounds 4 and 2 (each within the scatter of the next); then compound 1. At a limit, above all of these: compound 3.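

Trifluoromethyl in place of phenyl gives an at least 86-fold lower number from compound 3 to compound 4 (1.93 log units; beyond the scatter), so the position that lost activity with phenyl regains it with a group that has no ring. Trifluoromethyl in place of isopropyl gives a 1.2-fold lower number from compound 2 to compound 4 (0.08 log units; within the scatter), while in place of methyl it gives a 4.6-fold lower number from compound 1 to compound 4 (0.66 log units; beyond the scatter), so two groups of different atoms both go with the same gain over methyl. Compound 3 stands at a limit of the assay: the limit of > 4000 nM in this assay, at which 1 of the 4 values shown sits.

The compounds shown leave open whether an amine or a methoxy group would serve here as well. They also leave open whether a longer chain, such as n-butyl, would bring a loss like that seen with phenyl.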